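The compounds below may be only part of what the source reports. "The series", "measured", "known", "first", "only" and "open" are said of these compounds alone.

Measured compounds:
compound 1, `C[C@@H](O)[C@H]1C(=O)N2C(C(=O)OCOC(=O)OC3CCCCC3)=C(S[C@@H]3CN[C@H](C(=O)Nc4cccc(C(=O)O)c4)C3)[C@H](C)[C@H]12`: > 95%
compound 2, `CC(C)OC(=O)C1=C(S[C@@H]2CN[C@H](C(=O)Nc3cccc(C(=O)O)c3)C2)[C@H](C)[C@@H]2[C@@H]([C@@H](C)O)C(=O)N12`: > 95%

Compound 1 `C[C@@H](O)[C@H]1C(=O)N2C(C(=O)OCOC(=O)OC3CCCCC3)=C(S[C@@H]3CN[C@H](C(=O)Nc4cccc(C(=O)O)c4)C3)[C@H](C)[C@H]12` and compound 2 `CC(C)OC(=O)C1=C(S[C@@H]2CN[C@H](C(=O)Nc3cccc(C(=O)O)c3)C2)[C@H](C)[C@@H]2[C@@H]([C@@H](C)O)C(=O)N12` share one core and differ only in the ester. In a physicochemical assay for metabolic stability, read by LC-MS, in phosphate buffer, with a stated time of 3 h, at pH 7.4, tested at 50 uM (on this read-out lower numbers stand for a less stable compound and higher numbers for a more stable compound), compound 1 gives > 95%, which is a limit of the assay and not a number. In this assay compound 2 likewise gives > 95%, again a limit of the assay. The step that the two limits leave unreadable from compound 1 to compound 2 therefore cannot be read, since the limit of > 95% in this assay, at which 2 of the 2 values shown sit, holds both values at the upper edge of the read-out.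

Compound 3 `CC(C)C(=O)OCOC(=O)C1=C(S[C@@H]2CN[C@H](C(=O)Nc3cccc(C(=O)O)c3)C2)[C@H](C)[C@@H]2[C@@H]([C@@H](C)O)C(=O)N12` differs from compound 2 by ((isopropylcarbonyl)oxy)methyl in place of isopropyl on an oxygen next to a carbonyl group. For the measured compounds named here, the only measured step, from compound 1 to compound 2, is unreadable in size, so it sets no direction for the new change; it shows only that both an isopropyl ester and a ((cyclohexyloxycarbonyl)oxy)methyl ester sit at the limit. On that footing compound 3 is expected to stay at the limit as well, with a step that the limit leaves unreadable from compound 2 to compound 3 of essentially nothing beyond the scatter. The estimate for compound 3 is therefore 97%, within the range 90% to 100%.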

Compound 3, percent of the compound remaining: > 95%
Compound 3: no number, only a limit; the forecaster's own chance of this, stated with the estimate: 80%; the middle value is on the limit's open side.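

In this assay compound 3 gives > 95% which is a limit of the assay and not a number. For the compounds shown here, no step among compound 1, compound 2 and compound 3 can therefore be read: the limit of > 95% in this assay, at which 3 of the 3 values shown sit. The compounds shown leave open whether, and how far, these three esters differ in this assay once away from that limit.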